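The compounds below may be only part of what the source reports. "The series", "measured", "known", "first", "only" and "open" are said of these compounds alone.

Measured so far:
compound 1, `Cc1ccsc1C(=O)OC(CCN(C)C)c1ccc(Cl)cc1` — in an assay on NIH3T3 cells with Urotensin-2 receptor (Homo sapiens) as the target (a higher number here means a larger maximal response, a lower number a smaller maximal response), compound 1 gives 119%
compound 2, `CN(C)CCC(NC(=O)c1ccc(N(C)C)cc1)c1ccc(Cl)cc1` — in this assay compound 2 gives 150%

Compound 1 stands lowest of the two numbers in this assay; its nearest neighbour is compound 2, whose value is higher by a margin beyond the usual scatter. Going by the values given here, no step between two measured compounds that differ in one place is available, so nothing here shows how a single change at the carbonyl carbon moves the maximal response.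

Compound 3, `CN(C)CCC(OC(=O)NCc1ccccc1)c1ccc(Cl)cc1`, is not yet measured. It differs from compound 1 in one place: benzylamino in place of 3-methylthiophen-2-yl on a carbonyl carbon. The shared core of compound 1 is kept.

With no comparable step shown, the expectation for compound 3 in this assay rests on compound 1 alone, and the step from compound 1 is expected to be small, a number 4 percentage points lower from compound 1 to compound 3 (within the scatter), not clearly beyond the scatter in either direction. For compound 3 the estimate is 115%, expected to lie between 85% and 145%.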

Compound 3, largest response reached (reported as efficacy), in percent of the reference or control that the assay uses: 180%
Compound 3: middle estimate off by 65 percentage points, on the low side; the measured number lies above the stated range.
By their numbers in this assay, from the lowest: compound 1; then compound 2; then compound 3.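

In this assay, going by these compounds alone, benzylamino in place of 3-methylthiophen-2-yl on a carbonyl carbon gives a number 61 percentage points higher from compound 1 to compound 3 (beyond the scatter), the first single-place step, and it shows that the maximal response changes clearly with the group at this position. The change replaces a five-membered aromatic ring bearing sulfur with a six-membered aromatic ring of carbon only and adds a hydrogen-bond donor, and this one step cannot separate these differences. No measurement shown gives a reason for the step.

Still open, on these data alone, is whether the response depends on the benzylamino nitrogen, the carbon linking it to the ring, or the ring itself. A methyl(benzyl)amino group, a phenethylamino group with its longer chain, or a plain phenyl group at the same carbonyl carbon would each address part of this question.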